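Fluorophenyl hydrazones of the shared core: shifting the fluorine

A few compounds are considered here, and "the series" means these few. Any claim that something is new, unique, unknown or untested is made for them only; others in the source may bear on it.

Compound 1 `COc1cc(C(=O)N/N=C/c2cccc(F)c2)cc(OC)c1OC` carries the shared core with a 3-fluorophenyl on the carbon with a double bond to nitrogen. Within the data shown here, in a functional assay on BGC-823 cells (Homo sapiens) for antiproliferative activity, read by MTT assay, tested at 5 uM (on this read-out higher numbers stand for a stronger effect at the one concentration tested and lower numbers for a weaker effect), compound 1 gives 44.8%, the highest of the two numbers known so far. Among the measured compounds shown here, compound 2 `COc1cc(C(=O)N/N=C/c2cccc(C(F)(F)F)c2)cc(OC)c1OC` gives 33.8% in this assay, and the step of a number 11 percentage points lower from compound 1 to compound 2 (beyond the scatter) is the only measured step in the set.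

Compound 3 `COc1cc(C(=O)N/N=C/c2ccccc2F)cc(OC)c1OC` is not yet measured. It differs from compound 1 by 2-fluorophenyl in place of 3-fluorophenyl on a carbon with a double bond to nitrogen. For the measured compounds named here, the one measured step, a number 11 percentage points lower from compound 1 to compound 2 (beyond the scatter), concerns a change of the group itself on the aromatic carbon rather than a change of where the fluorine sits, so it bears only loosely on compound 3. Going by the values given here, no measured step of the present kind exists, and the two known values lie close together. In this assay a step of a number 1.8 percentage points lower from compound 1 to compound 3 (within the scatter) is therefore expected, that is, none beyond the scatter. Compound 3 is estimated at 43% in this assay, with a range from 27% to 59%.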

Compound 3, a percentage reported as inhibition, at one concentration (the size of the read-out at that concentration, not a potency): 76.5%
Estimate against measurement, compound 3: 33.5 percentage points below; the whole stated range lies below it.
By their numbers in this assay, from the lowest: compound 2; then compound 1; then compound 3.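

In this assay, 2-fluorophenyl in place of 3-fluorophenyl on a carbon with a double bond to nitrogen gives a number 31.7 percentage points higher from compound 1 to compound 3 (beyond the scatter), so this aromatic group responds strongly to a change that leaves its atoms and computed counts the same and only joins them differently. The earlier step, a number 11 percentage points lower from compound 1 to compound 2 (beyond the scatter), came from trifluoromethyl in place of fluoro and went the other way, so the series now holds a large rise from moving the fluorine as well as a modest fall from changing the group. Nothing available explains the rise, and no measured property of compound 1 or compound 3 bears on it.

As far as these compounds go, it remains open whether the rise belongs to fluorine itself, or whether a chloro, methoxy or amino group in place of the fluoro group on the aromatic carbon of compound 3 would hold the number. The read-out also stands at a single concentration in one cell line, so it leaves open how the compounds compare in potency or whether the rise carries over to other cells.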